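Notes on the step from compound 2 to compound 3

The source may report more compounds than this note shows. Statements on the series, on what has been measured and on what is new or still open speak of the compounds shown alone.

Measured compounds:
compound 1 `COc1cc2cc(Oc3ccc(NC(=O)Nc4ccc(C)cc4)cc3)c(C)nc2cc1OC`: 130%
compound 2 `COc1cc2cc(Oc3ccc(NC(=O)Nc4cccc(C(F)(F)F)c4)cc3)c(C)nc2cc1OC`: -8.13%

In a functional assay on BT-549 cells (Homo sapiens) for inhibition, read by sulforhodamine B assay, with a stated time of 48 h, tested at 10 uM (on this read-out higher numbers stand for a weaker effect at the one concentration tested and lower numbers for a stronger effect), compound 1 gives 130%, and compound 2 gives -8.13%. Compound 2 thus stands at the lowest of the two numbers; the nearest neighbour is compound 1, and the difference is a number 138.1 percentage points lower from compound 1 to compound 2 (beyond the scatter). That single step is the only one recorded, and it changed the same aryl group on the same amide-type nitrogen that the next step alters.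

Compound 3 `COc1cc2cc(Oc3ccc(NC(=O)Nc4ccc(Cl)c(Cl)c4)cc3)c(C)nc2cc1OC` is not yet measured. The change is 3,4-dichlorophenyl in place of 3-(trifluoromethyl)phenyl on an amide-type nitrogen. Both the group leaving and the group entering are substituted phenyl rings without donors or acceptors, and compound 2 already sits at the strong end of the two values. Going by the values given here, the one measured step, a number 138.1 percentage points lower from compound 1 to compound 2 (beyond the scatter), bears on the step to compound 3 only by showing that the aryl substituent matters greatly in this assay; it gives no direct guide to the size of the present change. A step of a number 18.1 percentage points higher from compound 2 to compound 3 (beyond the scatter) is expected, roughly within the scatter. Compound 3 is estimated at 10%, between -30% and 60%.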

Compound 3, a percentage reported as activity, at one concentration (the size of the read-out at that concentration, not a potency): 28.1%
The estimate for compound 3 lay 18.1 percentage points below the measured number; measured number inside the range.
By their numbers in this assay, from the lowest: compound 2; then compound 3; then compound 1.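

In this assay, the aryl group on the amide-type nitrogen remains a sensitive point even when the exchange is between two rings with 0 hydrogen-bond donors and 0 hydrogen-bond acceptors: 3,4-dichlorophenyl in place of 3-(trifluoromethyl)phenyl gives a number 36.2 percentage points higher from compound 2 to compound 3 (beyond the scatter). The 3,4-dichlorophenyl ring still retains much of the difference from 4-methylphenyl, with a number 101.9 percentage points lower from compound 1 to compound 3 (beyond the scatter), so the three rings now form a graded order at this place, with 3-(trifluoromethyl)phenyl giving the strongest effect, 3,4-dichlorophenyl an intermediate one and 4-methylphenyl the weakest, all separated beyond the scatter. Nothing available accounts for the difference between these rings.

The compounds shown leave open whether the order would hold for rings carrying other groups, such as a nitrile, a methoxy group or an amine, or for a ring with a single chlorine, since three aryl groups are too few to define a trend. Also open, from the compounds shown here alone, is whether the order would survive a change elsewhere in the shared core, and how it would look as potency, since each compound is represented by a reading at one concentration in one cell line.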